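The source may hold more compounds than are shown below. What is called first, only, known or untested is meant among the compounds shown, and "the series" means these compounds.

Measured so far in a functional assay on HCT-116 cells (Homo sapiens) for cytotoxicity, read by MTT assay, with a stated time of 48 h; on this read-out higher numbers stand for weaker inhibition of growth and lower numbers for stronger inhibition of growth
- compound 1 `CC(C)n1c(C(F)(F)F)nc2cc(Cl)c(Cl)cc21` gives 81900 nM
- compound 2 `FC(F)(F)c1nc2cc(Cl)c(Cl)cc2n1Cc1ccccc1` gives 8600 nM
- compound 3 `CCc1nc2cc(Cl)c(Cl)cc2n1C1CCCC1` gives 38000 nM

Compound 3 holds the middle of the three numbers. It lies closer to compound 1 than to compound 2, and beyond the scatter from both. The next compound is compound 4 `FC(F)(F)c1nc2cc(Cl)c(Cl)cc2n1C1CCCC1`, which differs from compound 3 by trifluoromethyl in place of ethyl on an aromatic carbon, next to the ring atom that bears a cyclopentyl group.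

For the measured compounds named here, no measured pair tests this exchange. Going by the values given here, the only measured step (a 9.5-fold lower number from compound 1 to compound 2 (0.98 log units; beyond the scatter)) is benzyl in place of isopropyl on an aromatic nitrogen, so it concerns another place. Compound 1 (81900 nM) and compound 2 (8600 nM) both carry trifluoromethyl, and their values enclose that of compound 3 (38000 nM). This gives no direction, so no step beyond the scatter is expected, and that expectation is weakly supported. The expected step in this assay is small (a 1.3-fold lower number from compound 3 to compound 4 (0.10 log units; within the scatter)) and would stay within the scatter. For compound 4 the estimated value is 30000 nM with an expected range from 10000 nM to 80000 nM in this read-out.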

Compound 4, concentration for 50% growth inhibition: 22000 nM
Compound 4: the middle estimate sits 1.4-fold (0.13 log units) above what was measured; the measured number falls inside the stated range.
By their numbers in this assay, from the lowest: compound 2; then compounds 4 and 3 (each within the scatter of the next); then compound 1.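

In this assay, the exchange at this position can now be read directly: a 1.7-fold lower number from compound 3 to compound 4 (0.24 log units; within the scatter) shows that trifluoromethyl in place of ethyl on an aromatic carbon, between two ring nitrogen atoms, stays within the scatter when cyclopentyl is the group on the nitrogen. With trifluoromethyl held fixed, the group on the nitrogen gives steps beyond the scatter, seen in a 2.6-fold higher number from compound 2 to compound 4 (0.41 log units; beyond the scatter) for cyclopentyl in place of benzyl and in a 3.7-fold lower number from compound 1 to compound 4 (0.57 log units; beyond the scatter) for cyclopentyl in place of isopropyl. No supporting data explain these steps.

Ethyl appears only with cyclopentyl on the nitrogen, so it remains open whether the exchange would also stay within the scatter with benzyl or isopropyl there. Going by these compounds, how an amine or a longer chain on that aromatic carbon would read also remains open.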